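A Furan Exchange in a Closely Grouped Series

The compounds below may be only part of what the source reports. "The series", "measured", "known", "first", "only" and "open" are said of these compounds alone.

compound 1 `Cc1ccc(-c2cc(-c3ccoc3)cc(-c3ccc(Cl)s3)n2)o1` gives 790 nM
compound 2 `Cc1cccc(-c2cc(-c3ccoc3)cc(-c3ccc(Cl)s3)n2)c1` gives 880 nM
compound 3 `Clc1cccc(-c2cc(-c3ccoc3)cc(-c3ccc(Cl)s3)n2)c1` gives 950 nM

All three compounds were measured in a functional assay on HCT-15 cells (Homo sapiens) for cytotoxicity, read by ELISA, with a stated time of 4 days (on this read-out lower numbers stand for stronger inhibition and higher numbers for weaker inhibition), and lie close together. Compound 3 stands level with the other two, with a 1.1-fold higher number from compound 2 to compound 3 (0.03 log units; within the scatter) and a 1.2-fold higher number from compound 1 to compound 3 (0.08 log units; within the scatter) as its distances.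

Compound 4 `Clc1cccc(-c2cc(-c3ccc(Cl)o3)cc(-c3ccc(Cl)s3)n2)c1` keeps the 3-chlorophenyl and 5-chlorothiophen-2-yl groups of compound 3 and differs opposite the ring nitrogen, where 5-chlorofuran-2-yl in place of furan-3-yl on an aromatic carbon marks 5-chlorofuran-2-yl in place of furan-3-yl on an aromatic carbon. For the measured compounds named here, all three measured compounds carry furan-3-yl at that place, so no measured step speaks to it directly. The steps at hand change another group: a 1.1-fold higher number from compound 1 to compound 2 (0.05 log units; within the scatter) and a 1.2-fold higher number from compound 1 to compound 3 (0.08 log units; within the scatter) and a 1.1-fold higher number from compound 2 to compound 3 (0.03 log units; within the scatter) all stay within the scatter. They show little movement in this assay when that other group changes, but they cannot show what the new furan will do.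

The expectation therefore starts from compound 3 at 950 nM and assumes no shift beyond the scatter in either direction. The estimated change is a 1.2-fold lower number from compound 3 to compound 4 (0.07 log units; within the scatter) and nothing larger is expected. Going by these compounds, for compound 4 the expected value is 800 nM with an estimated range from 280 nM to 2300 nM and that range is kept wide, as this place is untested.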

Compound 4, half-maximal inhibitory concentration: > 50000 nM
Compound 4: no number, only a limit (the forecaster's own chance of this, stated with the estimate: 5%); at least 62-fold (1.79 log units) between middle value and limit.
By their numbers in this assay, from the lowest: compounds 1, 2 and 3 (each within the scatter of the next). At a limit, above all of these: compound 4.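

In this assay, for the compounds shown here, the place opposite the ring nitrogen turns out to matter far more than the earlier compounds could suggest: an at least 52-fold higher number from compound 3 to compound 4 (1.72 log units; beyond the scatter), the first step to lie beyond the scatter, while the group changed among the earlier compounds left their numbers within the scatter of one another. Compound 4 gives > 50000 nM, which is a limit of the assay and not a number: the limit of > 50000 nM in this assay, at which 1 of the 4 values shown sits A single exchange at this place, with furan-3-yl leaving and 5-chlorofuran-2-yl entering, is therefore enough to carry the series from a closely grouped set of values to that limit, so this place is sensitive to change in a way the other place was not within the compounds shown.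

The compounds shown do not separate the added chlorine from the shift in how the furan is attached, since neither plain furan-2-yl nor 5-chlorofuran-3-yl stands among them. They also leave open how other groups at this place, such as a phenyl, an amine or a carboxylic acid, would fare in this assay.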